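Acyl variation on the sulfonamide side chain: compound 4

This account rests on a few compounds, and the source may have more. Where it says the series, first, only, none or still open, it means among the compounds named here.

Three members of the series have numbers in an ADME assay on microsomes from liver (Homo sapiens) for metabolic stability, with a stated time of 10 min; on this read-out lower numbers stand for a less stable compound and higher numbers for a more stable compound. Compound 1 `CCCCCNc1nc(Nc2ccc([N+](=O)[O-])cc2)nc(OCC(F)(F)F)n1` gives 74%. Compound 2 `O=C(NS(=O)(=O)CCNC(=O)C1CC1)c1ccc(Nc2nc(NC3(c4ccc(Cl)cc4)CC3)nc(OCC(F)(F)F)n2)cc1` gives 90% in this assay, the highest of the three numbers, with compound 3 `CC(C)(C)CNCCS(=O)(=O)NC(=O)c1ccc(Nc2nc(NC3(c4ccc(Cl)cc4)CC3)nc(OCC(F)(F)F)n2)cc1` nearest at 89% and compound 1 furthest, its number lower beyond the scatter. For the measured compounds named here, the one single-point step available, a number 1 percentage points lower from compound 2 to compound 3 (within the scatter), comes from neopentyl in place of cyclopropylcarbonyl on the amine nitrogen and lies within the scatter.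

Compound 4 `CC(=O)NCCS(=O)(=O)NC(=O)c1ccc(Nc2nc(NC3(c4ccc(Cl)cc4)CC3)nc(OCC(F)(F)F)n2)cc1` is the next member. It differs from compound 2 by methyl in place of cyclopropyl on a carbonyl carbon. This change sits at the same terminal acyl group that the step from compound 2 to compound 3 removed altogether, and that larger change left the number in this assay unmoved beyond the scatter. Going by the values given here, no other measured pair touches this position. The expectation for compound 4 is therefore a step no larger than the scatter, a number 2 percentage points lower from compound 2 to compound 4 (within the scatter), with no direction that the data can support. Compound 4 is estimated at 88% in this assay, with a range from 78% to 96%.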

Compound 4, percent of the compound remaining: 95%
Compound 4: the middle estimate sits 7 percentage points below what was measured; measured number inside the range.
By their numbers in this assay, from the lowest: compound 1; then compounds 3, 2 and 4 (each within the scatter of the next).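

In this assay, for the compounds shown here, the exchange on the carbonyl carbon gives a number 5 percentage points higher from compound 2 to compound 4 (within the scatter) and so is the first direct reading at this place: cyclopropyl gives way to methyl, with three carbon atoms and the ring leaving and one carbon entering, and the step stays within the scatter. The second new step, a number 6 percentage points higher from compound 3 to compound 4 (within the scatter) and likewise within the scatter, sets acetyl against neopentyl on the amine nitrogen, so cyclopropylcarbonyl, acetyl and neopentyl on this nitrogen are now linked by steps that all lie within the scatter, and the read-out does not separate these three groups in these compounds. No measurement at hand accounts for either step.

The compounds shown leave open whether a group of another kind on this nitrogen, such as a carboxylic acid, a longer alkyl chain or a benzoyl group, would give a step beyond the scatter. They also leave open whether the exchange of cyclopropylcarbonyl for acetyl would read the same on a different core, since both steps rest on a single shared core.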